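Selenium in place of sulfur: notes toward compound 4

The source may report more compounds than this note shows. Statements on the series, on what has been measured and on what is new or still open speak of the compounds shown alone.

Measured in a functional assay on HT-29 cells (Homo sapiens) for cytotoxicity, read by MTT assay, with a stated time of 72 h; a higher number here means a weaker inhibitor of growth, a lower number a stronger inhibitor of growth:
Compound 1, `C[Se]/C(=N\C(=O)c1cc2ccccc2s1)NC(=O)c1cc2ccccc2s1`. Compound 1 gives only a limit, > 100000 nM.
Compound 2, `CS/C(=N\C(=O)c1cc2ccccc2s1)NC(=O)c1cc2ccccc2s1`. Compound 2 gives 88200 nM.
Compound 3, `CS/C(=N\C(=O)c1cc(-c2ccccc2)nc2ccccc12)NC(=O)c1cc(-c2ccccc2)nc2ccccc12`. Compound 3 gives only a limit, > 100000 nM.

For the measured compounds named here, the one counted step among the measured compounds runs an at least 1.1-fold higher number from compound 2 to compound 1 (0.05 log units; that floor lies within the scatter); the change behind it is a group of 2 heavy atoms (1 carbon, 1 selenium; no ring) in place of a group of 2 heavy atoms (1 carbon, 1 sulfur; no ring), on a carbon with a double bond to nitrogen. How the core of compound 3 differs from the core of compound 2 is not broken down here.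

Not yet measured: compound 4, `C[Se]/C(=N\C(=O)c1cc(-c2ccccc2)nc2ccccc12)NC(=O)c1cc(-c2ccccc2)nc2ccccc12`. Its difference from compound 3 is a group of 2 heavy atoms (1 carbon, 1 selenium; no ring) in place of a group of 2 heavy atoms (1 carbon, 1 sulfur; no ring), on a carbon with a double bond to nitrogen, the same change as from compound 2 to compound 1, at a place described in identical words.

Going by the values given here, the single measured step did not lower the number. Compound 3 already sits at the limit of > 100000 nM in this assay, at which 2 of the 3 values shown sit. Compound 1 sits there too. The expected step in this assay is a step that the limit leaves unreadable from compound 3 to compound 4, carrying the same direction as the measured step. Compound 4 is therefore expected to give 160000 nM, within 90000 nM to 350000 nM, and most likely to be reported only as a limit.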

Compound 4, concentration for total growth inhibition: 90700 nM
Estimate against measurement, compound 4: 1.8-fold (0.25 log units) above; the range from low to high includes it.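

In this assay, putting the selenium-bearing group in place of methylsulfanyl on the carbon with a double bond to nitrogen gives an at least 1.1-fold lower number from compound 3 to compound 4 (0.04 log units; that floor lies within the scatter). This shows that the change can be placed on the second core with a readable value for compound 4, but it does not show that the change carries over from one core to the other in the same way, or in a different one: the same change on two cores in this assay, an at least 1.1-fold higher number (0.05 log units; that floor lies within the scatter) from compound 2 to compound 1 and an at least 1.1-fold lower number (0.04 log units; that floor lies within the scatter) from compound 3 to compound 4; the limit leaves it open whether they differ

Compound 3 gives > 100000 nM, which is a limit and not a number.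

The compounds shown hold only methylsulfanyl and the selenium-bearing group at this place, so it remains open how a longer chain, such as butyl, or an amine there would read in this assay. Also open, as far as these compounds go, is whether any group at this place moves the number beyond the usual scatter on either core.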